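Fluorine on the benzyl ring of two propargylamide-free cores

The compounds below may be only part of what the source reports. "The series", "measured", "known", "first", "only" and "open" are said of these compounds alone.

Measured compounds:
compound 1 `C#CCN(Cc1ccc(OCc2cccc(F)c2)cc1)[C@@H](C)C(N)=O` — 530 nM
compound 2 `NC(=O)[C@@H]1CCN1Cc1ccc(OCc2cccc(F)c2)cc1` — 21 nM
compound 3 `C#CCN(Cc1ccc(OCc2cccc(F)c2)cc1F)[C@@H](C)C(N)=O` — 93 nM

In an assay on Sf9 cells for inhibition of Amine oxidase [flavin-containing] B (Homo sapiens), with stated times of 15 min and 60 min (a lower number here means a stronger inhibitor, a higher number a weaker inhibitor), compound 2 gives the lowest of the three numbers, beyond the scatter from both others. The difference between the core of compound 2 and the core of compound 1 is not broken down here. Compound 3 differs from compound 1 by fluoro in place of hydrogen on an aromatic carbon; that step gave a 5.7-fold lower number from compound 1 to compound 3 (0.76 log units; beyond the scatter). Compound 4 `NC(=O)[C@@H]1CCN1Cc1ccc(OCc2cccc(F)c2)cc1F` is not yet measured; it differs from compound 2 by fluoro in place of hydrogen on an aromatic carbon. This is the same kind of change, though in compound 1 the new fluorine sits ortho to a large group, while in compound 2 it sits ortho to a (2-carbamoylazetidin-1-yl)methyl group (8 heavy atoms). Resting on a 5.7-fold lower number from compound 1 to compound 3 (0.76 log units; beyond the scatter), a somewhat smaller step is expected, since compound 2 already gives 21 nM: an expected 3.0-fold lower number from compound 2 to compound 4 (0.48 log units; beyond the scatter). Compound 4 is estimated at 7 nM in this assay, within 2.5 nM to 20 nM.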

Compound 4, half-maximal inhibitory concentration: 26 nM
For compound 4 the middle estimate is 3.7-fold (0.57 log units) below the measured one, and the stated range ends below it.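

In this assay, fluoro in place of hydrogen on an aromatic carbon gave a 1.2-fold higher number from compound 2 to compound 4 (0.09 log units; within the scatter) on the core of compound 2, so the earlier step did not repeat there. The same change thus behaved differently on the two cores: the same change on two cores in this assay, a 5.7-fold lower number (0.76 log units; beyond the scatter) from compound 1 to compound 3 and a 1.2-fold higher number (0.09 log units; within the scatter) from compound 2 to compound 4, 7.1-fold (0.85 log units) apart, beyond the scatter of two such steps. Going by these compounds alone, this shows that the step seen on the core of compound 1 cannot be carried unchanged to the core of compound 2, but with only one pair on each core it does not show what sets the two cores apart or how a further core would respond.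

The compounds shown leave open how chloro, methyl or methoxy at the same aromatic carbon would compare with fluoro on either core.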